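The source may hold more compounds than are shown below. What is called first, only, known or untested is meant among the compounds shown, and "the series" means these compounds.

Measured in an ADME assay on the whole organism with Oryza sativa as the target, tested at 0.1 uM; on this read-out higher numbers stand for a weaker effect at the one concentration tested and lower numbers for a stronger effect:
compound 1 `C[C@@H](NC(=O)Nc1cccc(Cl)c1)c1ccccc1` gives 97%
compound 2 `C[C@@H](NC(=O)Nc1cc(Cl)ccc1Cl)c1ccccc1` gives 99%

Compound 1 stands lowest of the two numbers in this assay, with compound 2 as its nearest neighbour, the gap between the two being within the scatter. Going by the values given here, the only step measured between compounds that differ in a single place is a number 2 percentage points higher from compound 1 to compound 2 (within the scatter). Compound 3 `C[C@@H](NC(=O)Nc1ccc(Cl)c(Cl)c1)c1ccccc1` is not yet measured; it differs from compound 1 by chloro in place of hydrogen on an aromatic carbon. Among the compounds with values here, the step from compound 1 to compound 2 is the one measured step that bears on this change, since it is also a chloro in place of hydrogen on an aromatic carbon, and it remained within the scatter. No shift beyond the scatter is therefore expected in this assay, and the step expected is a number 1 percentage points higher from compound 1 to compound 3 (within the scatter). Compound 3 is estimated at 98%, with a range from 91% to 103%.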

Compound 3, a percentage reported as activity, at one concentration (the size of the read-out at that concentration, not a potency): 98%
Estimate against measurement, compound 3: no gap at the digits printed; measured number inside the range.
By their numbers in this assay, from the lowest: compounds 1, 3 and 2 (each within the scatter of the next).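

In this assay, chloro in place of hydrogen on an aromatic carbon, ortho to a chloro group and para to a large group, gives a number 1 percentage points higher from compound 1 to compound 3 (within the scatter). Set beside a number 2 percentage points higher from compound 1 to compound 2 (within the scatter), this shows that the read-out stays within the scatter for the same change at a second place on the ring, and neither step goes against that. No measured property bears on this result, so the flat read-out has no explanation here.

Open, as far as these compounds go, is whether a group other than chloro at this position, such as an amine, a carboxylic acid or a longer chain, would move the read-out beyond the scatter. Also open, from the compounds shown here alone, is whether changes away from this ring, for instance at the amide hydrogen of the urea or on the unsubstituted phenyl group, would do so.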